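The compounds below may be only part of what the source reports. "The series", "measured", "known", "first", "only" and "open" are said of these compounds alone.

Working notes on the series around a shared core.

Of the compounds shown here, three have been measured in an assay on Sf21 cells for inhibition of high affinity nerve growth factor receptor (Homo sapiens), read by HTRF, with a stated time of 30 min, in the presence of a further agent that is not named here; a higher number here means a weaker inhibitor, a lower number a stronger inhibitor. Compound 1 `CC1(C)c2[nH]nc(NC(=O)c3ccccc3)c2CN1Cc1cccc(C#N)c1` gives 980 nM. Compound 2 `CC1(C)c2[nH]nc(NC(=O)c3ccccc3)c2CN1Cc1cccc(I)c1` gives 1360 nM. Compound 3 `CC1(C)c2[nH]nc(NC(=O)c3ccccc3)c2CN1Cc1cccc(Cl)c1` gives 670 nM. On these numbers compound 2 stands highest of the three; one of its neighbouring steps is a 1.4-fold higher number from compound 1 to compound 2 (0.14 log units; within the scatter) and lies within the scatter, while the gap to compound 3 is a 2.0-fold lower number from compound 2 to compound 3 (0.31 log units; beyond the scatter) and lies just beyond it. The remaining step, a 1.5-fold lower number from compound 1 to compound 3 (0.17 log units; within the scatter), is also within the scatter.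

Compound 4 `CC1(C)c2[nH]nc(NC(=O)c3ccccc3)c2CN1Cc1ccc(F)cc1F` has not yet been measured in this assay. It differs from compound 2 as follows: 2,4-difluorophenyl in place of 3-iodophenyl on a saturated chain carbon bound to an amine nitrogen in a ring. All three measured steps concern a single exchange of the group on the aromatic carbon of the benzyl part, and none of them involves fluorine or a second substituent on that ring, so the bearing is indirect. Those steps ranged from within the scatter to a modest size, with no large movement in either direction. A step of similar size is therefore expected for compound 4, most likely toward a lower number given that compound 2 is the highest of the measured values, amounting to a 1.5-fold lower number from compound 2 to compound 4 (0.18 log units; within the scatter). Compound 4 is estimated at 900 nM, with a range of 400 nM to 2500 nM.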

Compound 4, half-maximal inhibitory concentration: 2320 nM
Estimate against measurement, compound 4: 2.6-fold (0.41 log units) below; the measured number falls inside the stated range.
By their numbers in this assay, from the lowest: compounds 3, 1, 2 and 4 (each within the scatter of the next, the first and the last beyond it).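

The 2,4-difluorophenyl group is the only one so far that carries fluorine and more than one substituent on this ring, and it gives a step of a 3.5-fold higher number from compound 3 to compound 4 (0.54 log units; beyond the scatter) and one of a 2.4-fold higher number from compound 1 to compound 4 (0.37 log units; beyond the scatter), both modest and beyond the scatter in this assay. Against the 3-iodophenyl group, the step of a 1.7-fold higher number from compound 2 to compound 4 (0.23 log units; within the scatter) stays within the scatter, so compound 2 and compound 4 cannot be separated, and the exchange of the whole aryl group on the saturated chain carbon bound to the ring amine nitrogen has so far produced only modest steps, with compound 3 and compound 1 also within the scatter of each other. Nothing available accounts for these differences.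

From the compounds shown here alone, it remains open whether the result for compound 4 comes from the fluorine atoms themselves or from having more than one substituent, which a phenyl group carrying a single fluorine or a 2,4-dichlorophenyl group would separate. Also open, going by these compounds, is how this place responds to groups of another kind, such as a carboxylic acid, an aminomethyl group or a longer chain in place of the benzyl group, and whether the modest range seen here would hold for them.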